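The compounds below may be only part of what the source reports. "The series", "measured", "known", "first", "only" and "open" are said of these compounds alone.

Going by the values given here, in a functional assay on the whole organism (Hindlimb, strain albino) with Mus musculus as the target, in the maximal electroshock model, with a stated time of 0.5 h (a lower number here means that less compound is needed, a higher number that more compound is needed for the effect), compound 2 `CC(=O)N1N=C(Nc2nc3ccc(C)cc3s2)CC1OC1=CC=C1` gives 160 umol/kg, the highest of the three numbers so far. Compound 1 `COc1ccc(C2CC(Nc3nc4ccc(C)cc4s3)=NN2C(C)=O)cc1` gives 37.3 umol/kg and compound 3 `CC(=O)N1N=C(Nc2nc3ccc(C)cc3s2)CC1c1ccc(Cl)cc1` gives 25.5 umol/kg. These two stand within the scatter of each other, as a 1.5-fold lower number from compound 1 to compound 3 (0.17 log units; within the scatter) shows.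

Compound 4 `CC(=O)N1N=C(Nc2nc3ccc([N+](=O)[O-])cc3s2)CC1OC1=CC=C1` differs from compound 2 in one place: nitro in place of methyl on an aromatic carbon. In words, this is nitro in place of methyl on an aromatic carbon.

Among the compounds with values here, no measured step tests this exchange, since compound 1, compound 2 and compound 3 all carry the methyl. The nearest evidence is a 4.3-fold higher number from compound 1 to compound 2 (0.63 log units; beyond the scatter) and a 6.3-fold lower number from compound 2 to compound 3 (0.80 log units; beyond the scatter). Both are modest and beyond the scatter, but both change the group on the saturated ring carbon, which stays the same here. They say nothing about direction for the new change and serve only as a guide to how far one exchange has moved the numbers in this series, which sets the width of the range.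

The estimated 1.2-fold lower number from compound 2 to compound 4 (0.09 log units; within the scatter) is therefore expected to stay within the scatter, with no firm direction. For compound 4 the expected value is 130 umol/kg, with an estimated range from 45 umol/kg to 380 umol/kg.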

Compound 4, dose for half-maximal effect: 274 umol/kg
Beside the measured number, compound 4's estimate is 2.1-fold (0.32 log units) below it; the range from low to high includes it.
By their numbers in this assay, from the lowest: compounds 3 and 1 (each within the scatter of the next); then compounds 2 and 4 (each within the scatter of the next).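

In this assay, going by these compounds alone, a 1.7-fold higher number from compound 2 to compound 4 (0.23 log units; within the scatter) is the only reading so far of the aromatic carbon that carries methyl in compound 1, compound 2 and compound 3, and it shows that nitro can take the place of methyl there without a shift beyond the scatter. The exchanges on the saturated ring carbon behave differently, since a 4.3-fold higher number from compound 1 to compound 2 (0.63 log units; beyond the scatter) and a 6.3-fold lower number from compound 2 to compound 3 (0.80 log units; beyond the scatter) are both printed as beyond the scatter, so within these compounds that site, and not the aromatic carbon, accounts for the clear differences. No measurement at hand bears on why nitro and methyl read alike here.

From the compounds shown here alone, this conclusion rests on one pair, both members of which carry the same four-membered ring group on the saturated ring carbon, so whether the exchange reads the same with the aromatic groups of compound 1 and compound 3 remains open. Also open, going by these compounds, is how far this tolerance extends at the aromatic carbon, for instance to an amine or a carboxylic acid in place of methyl.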